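The source may hold more compounds than are shown below. What is called first, only, known or untested is meant among the compounds shown, and "the series" means these compounds.

Compound 1 `COc1ccc(-c2c(S(=O)(=O)c3ccc(OC)cc3)cnc3cc(F)ccc23)cc1` gives 1.18 mL/min in an ADME assay on microsomes from liver (Homo sapiens) for metabolic stability, tested at 2.5 uM; a lower number here means slower removal, a higher number faster removal of the compound. Compound 2 `COc1ccc(-c2c(S(=O)(=O)c3cc(F)cc(F)c3)cnc3cc(F)ccc23)cc1` gives 1.51 mL/min in this assay, the step being a 1.3-fold higher number from compound 1 to compound 2 (0.11 log units; within the scatter). Going by the values given here, compound 2 thus has the higher of the two numbers so far, though its gap to compound 1 lies within the scatter. Compound 3 `COc1ccc(-c2c(S(=O)(=O)c3cc(Cl)cc(Cl)c3)cnc3cc(F)ccc23)cc1` differs from compound 2 by 3,5-dichlorophenyl in place of 3,5-difluorophenyl on a sulfonyl sulfur. Among the compounds with values here, the only step that bears on it, the one from compound 1 to compound 2, was within the scatter, so no step beyond the scatter is expected here either. Compound 3 is therefore estimated at 1.7 mL/min in this assay, between 0.9 mL/min and 3.3 mL/min, an expected step of a 1.1-fold higher number from compound 2 to compound 3 (0.05 log units; within the scatter).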

Compound 3, intrinsic clearance in a liver preparation (reported as CLH), per the amount of preparation that the assay uses: 1 mL/min
Compound 3: the middle estimate sits 1.7-fold (0.23 log units) above what was measured, within the range that was stated.
By their numbers in this assay, from the lowest: compounds 3, 1 and 2 (each within the scatter of the next).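

With 3,5-dichlorophenyl on the sulfonyl sulfur, this assay gives a 1.5-fold lower number from compound 2 to compound 3 (0.18 log units; within the scatter) and a 1.2-fold lower number from compound 1 to compound 3 (0.07 log units; within the scatter) as its two new steps. All three groups tested at this place, 4-methoxyphenyl, 3,5-difluorophenyl and 3,5-dichlorophenyl, therefore lie within the scatter of one another, so exchanging the two halogens on this ring shows no readable change. No measurement is available here to explain this result. From the compounds shown here alone, it remains open whether an amine or a carboxylic acid on the sulfonyl-bound ring would give a step beyond the scatter.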